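Aryl groups in place of methylsulfanyl: expected stability gain

The source may report more compounds than this note shows. Statements on the series, on what has been measured and on what is new or still open speak of the compounds shown alone.

Measured in an ADME assay on S9 fraction from liver (Rattus norvegicus) for metabolic stability, read by LC-MS, using NADPH, with a stated time of 30 min; a higher number here means that more of the compound is left, a lower number that less of the compound is left:
- compound 1 `CCCCCCCCc1ccc(OCC(=O)Cn2nnc(SC)n2)cc1`: < 5%.
- compound 2 `CCCCCCCCc1ccc(OCC(=O)Cn2nnc(-c3ccccc3)n2)cc1`: 33%.
- compound 3 `CCCCCCCCc1ccc(OCC(=O)Cn2nnc(-c3ccc(Cl)cc3)n2)cc1`: 74%.

Compound 1 gives a read-out that is not a number but a limit of the assay, namely (the limit of < 5% in this assay, at which 1 of the 3 values shown sits). Compound 2 and compound 3 give numbers, and both aryl replacements of the methylsulfanyl group move the read-out upward: a number at least 28 percentage points higher from compound 1 to compound 2 (beyond the scatter), and a number at least 69 percentage points higher from compound 1 to compound 3 (beyond the scatter). Within the aryl pair, a number 41 percentage points higher from compound 2 to compound 3 (beyond the scatter).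

The next compound, compound 4 `CCCCCCCCc1ccc(OCC(=O)Cn2nnc(-c3ccncc3)n2)cc1`, is not yet measured. Its change from compound 1 is pyridin-4-yl in place of methylsulfanyl on an aromatic carbon. The two steps from compound 1 to the aryl compounds both bear on it, one at least modest and one large, so a rise beyond the scatter in this assay is expected here too, with the phenyl case of compound 2 as the nearer comparison and the 4-chlorophenyl case of compound 3 marking the upper side.

Compound 4 is therefore expected at about 35%, in the range 10% to 70%. This estimate means a step of a number at least 30 percentage points higher from compound 1 to compound 4 (beyond the scatter).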

Compound 4, percent of the compound remaining: < 5%
Compound 4: no number, only a limit; the forecaster's own chance of this, stated with the estimate: 10%; middle value at least 30 percentage points away from the limit.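

In this assay, an aryl group at this position does not by itself bring a gain, as pyridin-4-yl in place of the carbon-only aryl groups gives a number at least 28 percentage points lower from compound 2 to compound 4 (beyond the scatter) and a number at least 69 percentage points lower from compound 3 to compound 4 (beyond the scatter). Compound 4 gives < 5%, a limit of the assay and not a number. The step between compound 1 and compound 4 cannot be read, as both compounds sit at the same limit: the limit of < 5% in this assay, at which 2 of the 4 values shown sit.

Going by these compounds, how far compound 4 and compound 1 truly differ remains open, as does whether a chloro group on the pyridin-4-yl ring would bring a rise like that seen from compound 2 to compound 3. On these data alone, it is also open how a 4-methoxyphenyl or a cyclohexyl group would read at this position on the shared core.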